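A Chloro-to-Trifluoromethyl Swap on a Urea Terminal Ring

A few compounds are considered here, and "the series" means these few. Any claim that something is new, unique, unknown or untested is made for them only; others in the source may bear on it.

Of the compounds shown here, three sharing one core have been measured in a functional assay on U-251 cells (Homo sapiens) for inhibition, read by sulforhodamine B assay, with a stated time of 48 h; on this read-out lower numbers stand for stronger inhibition of growth and higher numbers for weaker inhibition of growth. Compound 1 `O=C(Nc1cccc(-n2cc(-c3ccncc3)c(-c3ccc(Cl)c(O)c3)n2)c1)Nc1ccc(Cl)c(Cl)c1` gives 1510 nM. Compound 2 `COc1cc(-c2nn(-c3cccc(NC(=O)c4cccc(C(F)(F)F)c4)c3)cc2-c2ccncc2)ccc1Cl` gives 1620 nM, a value that sits within the usual scatter of compound 1, so the two cannot be told apart. Compound 3 `O=C(Nc1cccc(-n2cc(-c3ccncc3)c(-c3ccc(Cl)c(O)c3)n2)c1)Nc1cc(C(F)(F)F)cc(C(F)(F)F)c1` gives 463 nM, which is beyond the scatter and stands as the lowest of the three numbers; compound 1 is the second highest.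

Compound 4 `O=C(Nc1cccc(-n2cc(-c3ccncc3)c(-c3ccc(Cl)c(O)c3)n2)c1)Nc1ccc(Cl)c(C(F)(F)F)c1` is not yet measured. It differs from compound 1 in one place: trifluoromethyl in place of chloro on an aromatic carbon. The trifluoromethyl group enters on an aromatic carbon of a six-membered aromatic ring of carbon only, ortho to a chloro group and meta to a large group.

Compound 3, which carries two trifluoromethyl groups on the same terminal ring, gives 463 nM, so a single trifluoromethyl is expected to move the number part of the way in that direction. For compound 4 the step of a 1.7-fold lower number from compound 1 to compound 4 (0.22 log units; within the scatter) is expected to be modest, toward stronger inhibition of growth, and close to the edge of the scatter. Compound 4 is therefore estimated at 900 nM, with a range from 400 nM to 2000 nM.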

Compound 4, concentration for 50% growth inhibition: 548 nM
Estimate against measurement, compound 4: 1.6-fold (0.22 log units) above; low and high end bracket the measured number.
By their numbers in this assay, from the lowest: compounds 3 and 4 (each within the scatter of the next); then compounds 1 and 2 (each within the scatter of the next).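

In this assay, replacing one chloro with trifluoromethyl on the terminal ring of the urea gives a 2.8-fold lower number from compound 1 to compound 4 (0.44 log units; beyond the scatter) and so moves the number by more than the usual scatter. Going by these compounds alone, this is the first reading of a single change here, since no two of the earlier compounds differed in only one place, and it shows that this aromatic carbon, ortho to a chloro group, responds to what is placed on it. Nothing measured here explains the gain, so it stands as an observation only.

On these data alone, two compounds at this position cannot show whether the response follows a trend, and what a nitrile or a dimethylamino group would do on the same aromatic carbon stays open. Also open, as far as these compounds go, is whether the remaining chloro, on the neighbouring ring carbon named in the 4-chloro-3-(trifluoromethyl)phenyl group, contributes anything to the number.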